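Chlorine Placement on the Phenyl Amide

The source may hold more compounds than are shown below. What is called first, only, known or untested is meant among the compounds shown, and "the series" means these compounds.

In a functional assay on A549 cells (Homo sapiens) for cytotoxicity, read by MTT assay, with a stated time of 48 h (on this read-out higher numbers stand for an effect only at larger amounts of compound and lower numbers for an effect already at smaller amounts), compound 1 `Cc1ccc(NC(=O)CN2C(=O)/C(=N\NC(=O)Cn3ccc(=O)c(O)c3C)c3ccccc32)cc1` gives 47500 nM. Compound 2 `Cc1c(O)c(=O)ccn1CC(=O)N/N=C1\C(=O)N(CC(=O)Nc2ccccc2Cl)c2ccccc21` reaches only the limit of this assay, > 100000 nM. That limit, (the limit of > 100000 nM in this assay, at which 1 of the 2 values shown sits), means the step of an at least 2.1-fold higher number from compound 1 to compound 2 (0.32 log units; beyond the scatter) is known only as a lower bound. Compound 3 `Cc1c(O)c(=O)ccn1CC(=O)N/N=C1\C(=O)N(CC(=O)Nc2cccc(Cl)c2)c2ccccc21` differs from compound 2 by 3-chlorophenyl in place of 2-chlorophenyl on an amide-type nitrogen. Among the compounds with values here, no measured step tests this change, and the one step seen is already at the edge of what this assay can report. Compound 3 is therefore expected near 90000 nM, between 30000 nM and 300000 nM, most likely again at the limit. The expected step of an at least 1.1-fold lower number from compound 2 to compound 3 (0.04 log units; that floor lies within the scatter) is none beyond the scatter.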

Compound 3, half-maximal effective concentration: 28000 nM
Compound 3: middle estimate off by 3.2-fold (0.51 log units), on the high side; measured number below the stated range.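

Moving the chlorine alone matters at this position: with the same atoms joined differently, 3-chlorophenyl in place of 2-chlorophenyl on the amide-type nitrogen gives an at least 3.5-fold lower number from compound 2 to compound 3 (0.55 log units; beyond the scatter) in this assay. Replacing 4-methylphenyl with 3-chlorophenyl gives a 1.7-fold lower number from compound 1 to compound 3 (0.23 log units; within the scatter), so this assay does not separate these two groups. The step from the 2-chlorophenyl compound remains only a lower bound: the limit of > 100000 nM in this assay, at which 1 of the 3 values shown sits.

On these data alone, it remains open whether an amine or a carboxylic acid on the phenyl ring, in place of the chlorine, would keep this cytotoxicity.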